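The source may report more compounds than this note shows. Statements on the series, on what has been measured and on what is new or still open speak of the compounds shown alone.

Series notes. Compound 1 `CC1=CC[C@@H]([C@@](C)(O)CCCC(C)(C)NC(=S)NN)CC1` gives 760 nM in a functional assay on NCI/ADR cells (Homo sapiens) for cytotoxicity, read by sulforhodamine B assay; on this read-out lower numbers stand for stronger inhibition of growth and higher numbers for weaker inhibition of growth. Compound 2 `CC1=CC[C@@H]([C@@](C)(O)CCCC(C)(C)NC(=S)N/N=C\c2ccccc2)CC1` gives 6970 nM in this assay, and compound 3 `CC1=CC[C@@H]([C@@](C)(O)CCCC(C)(C)NC(=S)N/N=C\c2ccc(C)cc2)CC1` gives 6510 nM in this assay. The steps of a 9.2-fold higher number from compound 1 to compound 2 (0.96 log units; beyond the scatter) and an 8.6-fold higher number from compound 1 to compound 3 (0.93 log units; beyond the scatter) are both beyond the scatter, whereas the step of a 1.1-fold lower number from compound 2 to compound 3 (0.03 log units; within the scatter) lies within it. Compound 3 therefore stands second highest of the three numbers, close to compound 2 and well apart from compound 1.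

Compound 4 `COc1ccc(/C=N\NC(=S)NC(C)(C)CCC[C@](C)(O)[C@@H]2CC=C(C)CC2)cc1` has not been measured. Against compound 3 the change is methoxy in place of methyl on an aromatic carbon. Going by the values given here, the only measured step at an aromatic carbon of that kind, a 1.1-fold lower number from compound 2 to compound 3 (0.03 log units; within the scatter), stayed within the scatter; no measured compound carries a methoxy, so nothing among the known numbers speaks for or against a shift. The expectation for compound 4 in this assay is a step of a 1.0-fold lower number from compound 3 to compound 4 (0.00 log units; within the scatter) that remains within the scatter, leaving the number near that of compound 3. Compound 4 is thus estimated at 6500 nM, with a range from 3000 nM to 14000 nM.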

Compound 4, concentration for 50% growth inhibition: 6730 nM
Beside the measured number, compound 4's estimate is 1.0-fold (0.02 log units) below it; low and high end bracket the measured number.
By their numbers in this assay, from the lowest: compound 1; then compounds 3, 4 and 2 (each within the scatter of the next).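

Methoxy on the aromatic carbon, para to a large group, adds a third substituent at this place, and in this assay the steps of a 1.0-fold higher number from compound 3 to compound 4 (0.01 log units; within the scatter) and a 1.0-fold lower number from compound 2 to compound 4 (0.02 log units; within the scatter) show hydrogen, methyl and methoxy reading alike, where earlier only hydrogen and methyl could be compared. The step of an 8.9-fold higher number from compound 1 to compound 4 (0.95 log units; beyond the scatter) shows that compound 4 also remains apart from compound 1 despite carrying an oxygen-bearing substituent, so all three compounds with the aromatic ring now share that separation. No measurement is available that bears on why these three substituents read alike.

On these data alone, whether a group of another kind at this place, such as an amine, a carboxylic acid or a longer chain, would move the number remains open. Also open, as far as these compounds go, is whether any substituent on this ring can close the gap to compound 1.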